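Aryl change at the sulfoxide of a weakly active amide

This account rests on a few compounds, and the source may have more. Where it says the series, first, only, none or still open, it means among the compounds named here.

Compound 1 `CC(O)(C[S+]([O-])c1ccc(F)cc1F)C(=O)Nc1ccc([N+](=O)[O-])cc1C(F)(F)F`: > 100000 nM
Compound 2 `CC(O)(C[S+]([O-])c1ccc(OC(F)(F)F)cc1)C(=O)Nc1ccc(C#N)c(C(F)(F)F)c1`: 52100 nM
Compound 3 `CC(O)(C[S+]([O-])c1ccc(C(F)(F)F)cn1)C(=O)Nc1ccc(C#N)c(C(F)(F)F)c1`: 100000 nM; > 100000 nM (2 entries)

In a functional assay on DU-145 cells (Homo sapiens) for antiproliferative activity (a lower number here means a stronger inhibitor, a higher number a weaker inhibitor), compound 1 reaches only a limit of the assay, > 100000 nM, and no single number is reported for it. Compound 3 stands at the same edge of the assay, with entries of the several entries of compound 3 in this assay, 100000 nM; > 100000 nM (2 entries). Compound 2, on the other hand, gives a number in this assay, 52100 nM. Compound 1 therefore sits at the weak end of what is shown, where the assay stops counting, (the limit of > 100000 nM in this assay, at which 1 of the 3 values shown sits).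

Compound 4 `CC(O)(C[S+]([O-])c1ccccc1OC(F)(F)F)C(=O)Nc1ccc([N+](=O)[O-])cc1C(F)(F)F` differs from compound 1 by 2-(trifluoromethoxy)phenyl in place of 2,4-difluorophenyl on a sulfur. The three measured compounds vary at the anilide as well as at the sulfur, so no single change between them isolates what this aryl swap alone does in this assay. Without such a step, the step from compound 1 to compound 4 is expected to be no larger than the scatter: a number no higher from compound 1 to compound 4 (the limit leaves the size open). On that basis compound 4 is estimated at 100000 nM in this assay, within 30000 nM to 300000 nM, with a fair chance that the assay again reports only a limit.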

Compound 4, half-maximal inhibitory concentration: 31100 nM
Compound 4: the middle estimate sits 3.2-fold (0.51 log units) above what was measured, within the range that was stated.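

In this assay, among the compounds shown here, the pair formed by compound 1 and compound 4 is the first to isolate the aryl group on the sulfur, as the rest of the molecule stays the same. Replacing 2,4-difluorophenyl with 2-(trifluoromethoxy)phenyl gives an at least 3.2-fold lower number from compound 1 to compound 4 (0.50 log units; beyond the scatter), so this position can shift antiproliferative activity on its own, although compound 4, at 31100 nM, remains a weak inhibitor. The true size of the step stays open, as one end of it is only a limit of the assay: the limit of > 100000 nM in this assay, at which 1 of the 4 values shown sits.

The compounds shown do not reveal whether the difference belongs to the trifluoromethoxy group itself or to the loss of the two fluorines, nor whether the same aryl change would carry over to the nitrile-bearing anilide shared by compound 2 and compound 3. On these data alone, how a plain phenyl ring, or an aryl ring carrying an amine or a carboxylic acid, would behave on this sulfur also remains open.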